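Two dioxane acids and a phenylsulfanyl analogue

The source may report more compounds than this note shows. Statements on the series, on what has been measured and on what is new or still open speak of the compounds shown alone.

Compound 1 `O=C(O)CC/C=C\CC1COC(c2ccccc2Cl)OC1c1cccnc1` — 48 nM
Compound 2 `COc1ccc(OC(C)(C)C2OCC(C/C=C\CCC(=O)O)C(c3cccnc3)O2)cc1` — 41 nM

Of the compounds shown here, two have been tested so far in an assay for inhibition of Thromboxane-A synthase (Homo sapiens), using microsomes; a lower number here means a stronger inhibitor, a higher number a weaker inhibitor. Compound 1, with its shared core `O=C(O)CC/C=C\CC1COC(c2ccccc2Cl)OC1c1cccnc1`, gives 48 nM. Compound 2 `COc1ccc(OC(C)(C)C2OCC(C/C=C\CCC(=O)O)C(c3cccnc3)O2)cc1` gives 41 nM in this assay. Compound 2 carries the lower of the two numbers, but the gap to compound 1 is within the scatter, so the two cannot be told apart on this evidence. Going by the values given here, no step between two measured compounds that differ in one place is available, so nothing is known yet about how a single change at any one position moves the number.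

Compound 3 `CC(C)(Sc1ccccc1)C1OCC(C/C=C\CCC(=O)O)C(c2cccnc2)O1` is the next compound, not yet measured. It differs from compound 2 in one place: phenylsulfanyl in place of 4-methoxyphenoxy on a saturated chain carbon bound to two saturated chain carbons and a saturated ring carbon. Given that compound 1 and compound 2 sit so close together despite their differences, the step from compound 2 to compound 3 is expected to be small, a 1.2-fold higher number from compound 2 to compound 3 (0.09 log units; within the scatter), in no sure direction and not clearly beyond the scatter. Compound 3 is therefore estimated at 50 nM, with a range from 20 nM to 130 nM.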

Compound 3, half-maximal inhibitory concentration: 40 nM
Beside the measured number, compound 3's estimate is 1.3-fold (0.10 log units) above it; measured number inside the range.
By their numbers in this assay, from the lowest: compounds 3, 2 and 1 (each within the scatter of the next).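

In this assay, the change at this position gives a 1.0-fold lower number from compound 2 to compound 3 (0.01 log units; within the scatter). Going by these compounds alone, this is the first step that can be read at a single place: on a saturated chain carbon bound to two saturated chain carbons and a saturated ring carbon, phenylsulfanyl, with its 7 heavy atoms and 1 hydrogen-bond acceptor, stands in for 4-methoxyphenoxy, with its 9 heavy atoms and 2 hydrogen-bond acceptors, and the two compounds cannot be told apart. A second comparison, with a group of 10 heavy atoms in place of a group of 7 on a saturated ring carbon, gives a 1.2-fold lower number from compound 1 to compound 3 (0.08 log units; within the scatter), so this wider exchange also leaves the number within the scatter, and no information is available to explain either result.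

What the compounds shown leave open is whether this position would keep the number with a group lacking an aromatic ring altogether, such as an amine or a plain methyl group. They also do not show whether a substituent on the phenyl ring of phenylsulfanyl, such as a chlorine or a methoxy group, would produce a step beyond the scatter.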